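Working notes: exchange on the benzyl group of compound 3

The source may hold more compounds than are shown below. What is called first, only, known or untested is meant among the compounds shown, and "the series" means these compounds.

Measured in an ADME assay on A549 cells (Homo sapiens) for cytotoxicity, read by resazurin assay, with a stated time of 48 h; a lower number here means that less compound is tolerated, a higher number that more compound is tolerated:
- compound 1 `CC(C)Nc1ccc(NC(=O)c2cc(Cl)ccc2O)c(Cl)c1` gives (11000 nM)
- compound 2 `CCCCCCC(C)Nc1ccc(NC(=O)c2cc(Cl)ccc2O)c(Cl)c1` gives (23500 nM)
- compound 3 `O=C(Nc1ccc(NCc2cc(Cl)cc(Cl)c2)cc1Cl)c1cc(Cl)ccc1O` gives (13300 nM)

The number for compound 3 cannot be separated from either of the other two. The step to it from the short chain is small (a 1.2-fold higher number from compound 1 to compound 3 (0.08 log units; within the scatter)), and the step from the long chain is also small (a 1.8-fold lower number from compound 2 to compound 3 (0.25 log units; within the scatter)).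

Compound 4 `O=C(Nc1ccc(NCc2cccc(Br)n2)cc1Cl)c1cc(Cl)ccc1O` is still unmeasured. It carries 6-bromopyridin-2-yl in place of 3,5-dichlorophenyl on a saturated chain carbon bound to a nitrogen on an aromatic ring.

Within the data shown here, no measured pair makes this exchange, so the evidence is indirect. All three steps concern the substituent on the same nitrogen, and they replace far more of it than this change does. The largest is only modest (a 2.1-fold higher number from compound 1 to compound 2 (0.33 log units; beyond the scatter)), and it is the only one beyond the scatter. On that basis, no step beyond the scatter is expected in this assay, and no direction can be argued with confidence.

The estimated step is small (a 1.1-fold higher number from compound 3 to compound 4 (0.05 log units; within the scatter)).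

For compound 4 the expected value is (15000 nM), with an estimated range from 7000 nM to 30000 nM in this assay.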

Compound 4, half-maximal cytotoxic concentration: 92300 nM
The estimate for compound 4 lay 6.2-fold (0.79 log units) below the measured number; measured number above the stated range.
By their numbers in this assay, from the lowest: compounds 1, 3 and 2 (each within the scatter of the next, the first and the last beyond it); then compound 4.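

In this assay, the ring carried on the saturated chain carbon bound to the aromatic nitrogen proves to be a sensitive part of this substituent: 6-bromopyridin-2-yl in place of 3,5-dichlorophenyl gives the largest step among neighbouring exchanges so far (a 6.9-fold higher number from compound 3 to compound 4 (0.84 log units; beyond the scatter)), larger than the earlier chain extension (a 2.1-fold higher number from compound 1 to compound 2 (0.33 log units; beyond the scatter)). Compound 4 also stands clear of both compounds with an open chain on this nitrogen (a 3.9-fold higher number from compound 2 to compound 4 (0.59 log units; beyond the scatter); an 8.4-fold higher number from compound 1 to compound 4 (0.92 log units; beyond the scatter)), so it has the highest number of the four, with all of its steps beyond the scatter. Among these compounds, then, exchanging the ring alone moves the number further than replacing the entire substituent does, whether isopropyl, 1-methylheptyl or 3,5-dichlorobenzyl is the group replaced.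

This exchange brings in the ring nitrogen and the bromine and removes both chlorines at once, so the compounds shown cannot assign the step to any one of these changes; a pyridine ring without a halogen and a bromophenyl group on the same carbon would begin to separate them. Nothing available offers a measured explanation for the size of this step.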